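The compounds below may be only part of what the source reports. "The series", "measured", "known", "first", "only" and "open" are said of these compounds alone.

For the measured compounds named here, compound 1 `COc1cc(-c2nn(-c3cccc(NC(=O)c4cccc(C(F)(F)F)c4)c3)cc2-c2ccncc2)ccc1Cl` is one of two compounds measured here in a functional assay on NCI-H522 cells (Homo sapiens) for inhibition, read by sulforhodamine B assay, with a stated time of 48 h (on this read-out lower numbers stand for stronger inhibition of growth and higher numbers for weaker inhibition of growth), and in that assay compound 1 gives 3850 nM. The second measured compound, compound 2 `O=C(Nc1cccc(-n2cc(-c3ccncc3)c(-c3ccc(Cl)c(O)c3)n2)c1)Nc1cc(C(F)(F)F)cc(C(F)(F)F)c1`, gives 2510 nM in this assay. Going by the values given here, the two numbers lie within the usual scatter of each other, so nothing can be said about an order between compound 1 and compound 2; compound 2 also differs from compound 1 in more than one place, so no single step connects them.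

The unmeasured compound 3 `COc1cc(-c2nn(-c3cccc(NC(=O)Nc4ccc(Cl)c(C(F)(F)F)c4)c3)cc2-c2ccncc2)ccc1Cl` is reached from compound 1 by one change: (4-chloro-3-(trifluoromethyl)phenyl)amino in place of 3-(trifluoromethyl)phenyl on a carbonyl carbon. This turns the amide of compound 1 into a urea and adds a chlorine to the aryl ring. Among the compounds with values here, no measured pair shows this exact change, so its effect must be guessed. Since compound 2, a urea, gives 2510 nM and sits within the scatter of compound 1, the step is expected to be small; a step of a 1.5-fold lower number from compound 1 to compound 3 (0.19 log units; within the scatter) is estimated, at most a modest move toward lower numbers. Compound 3 is thus expected to give about 2500 nM in this assay, with a range from 1000 nM to 6500 nM.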

Compound 3, concentration for total growth inhibition: 6060 nM
Compound 3: middle estimate off by 2.4-fold (0.38 log units), on the low side; the measured number falls inside the stated range.
By their numbers in this assay, from the lowest: compounds 2, 1 and 3 (each within the scatter of the next, the first and the last beyond it).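

For the compounds shown here, compound 1 and compound 3 form the first pair here that differs in one place, and in this assay the exchange on the carbonyl carbon gives a 1.6-fold higher number from compound 1 to compound 3 (0.20 log units; within the scatter). The read-out therefore does not separate the amide of compound 1 from the urea of compound 3: on this carbonyl carbon, (4-chloro-3-(trifluoromethyl)phenyl)amino can stand in place of 3-(trifluoromethyl)phenyl with no shift that rises above the scatter. No measurement bearing on this result is available to explain it.

Going by these compounds alone, the single step still joins two differences, the amino nitrogen and the chlorine, and a urea carrying plain 3-(trifluoromethyl)phenyl, or an amide carrying 4-chloro-3-(trifluoromethyl)phenyl, would be needed to tell their contributions apart. As far as these compounds go, it also remains open how this carbonyl carbon would respond to a quite different partner, such as a morpholine, a piperazine or a benzyl group, or to a methyl or a methoxy group in place of the chlorine on the aryl ring.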